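This account rests on a few compounds, and the source may have more. Where it says the series, first, only, none or still open, it means among the compounds named here.

Compound 1, with the structure `Cn1nc2c(=O)n(CC3(O)CCN(Cc4ccc(-c5ccco5)cc4Cl)CC3)cnc2c1-c1ccc(CNCCO)cc1`, gives the lowest number of the three measured compounds in an assay on isolated protein for inhibition of ubiquitin carboxyl-terminal hydrolase 7 (Homo sapiens), with stated times of 30 min and 2 h (on this read-out higher numbers stand for weaker inhibition and lower numbers for stronger inhibition), at 8.2 nM. Compound 3, with the structure `Cn1nc2c(=O)n(CC3(O)CCN(Cc4ccc(-c5cnco5)cc4Cl)CC3)cnc2c1-c1ccc(CN)cc1`, gives 71.6 nM, and compound 2, with the structure `Cn1nc2c(=O)n(CC3(O)CCN(Cc4ccc(-c5ccsc5Cl)cc4Cl)CC3)cnc2c1-c1ccc(CN)cc1`, gives 453 nM in this assay. Within the data shown here, the only single-point comparison among them is a 6.3-fold lower number from compound 2 to compound 3 (0.80 log units; beyond the scatter), a change on the aromatic ring that hangs from the chlorophenyl group, far from the site altered here.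

Compound 4, with the structure `CN(C)Cc1ccc(-c2c3ncn(CC4(O)CCN(Cc5ccc(-c6ccco6)cc5Cl)CC4)c(=O)c3nn2C)cc1`, differs from compound 1 by dimethylamino in place of (2-hydroxyethyl)amino on a saturated chain carbon bound to an aromatic carbon. Among the measured compounds shown here, no measured step touches this part of the molecule, so the comparison between compound 2 and compound 3 offers no direct guide, and the step from compound 1 to compound 4 has to be judged without a precedent of the same kind. Given that the change is small in size and leaves the rest of the molecule untouched, the expectation is a step that stays within the usual scatter, in either direction, as expressed by a 1.5-fold higher number from compound 1 to compound 4 (0.17 log units; within the scatter). Compound 4 is therefore estimated to give about 12 nM in this assay, with a likely range from 4 nM to 40 nM.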

Compound 4, half-maximal inhibitory concentration: 131 nM
The estimate for compound 4 lay 11-fold (1.04 log units) below the measured number; measured number above the stated range.
By their numbers in this assay, from the lowest: compound 1; then compounds 3 and 4 (each within the scatter of the next); then compound 2.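

In this assay, the change at this position gives a 16-fold higher number from compound 1 to compound 4 (1.20 log units; beyond the scatter), the first measured sign that the group on the saturated chain carbon bound to an aromatic carbon strongly affects the read-out. The earlier step changed a different part of the molecule and said nothing about this site, whereas this result shows that swapping one small amine for another here can weaken inhibition well beyond the scatter. The two groups differ in more than one respect, as (2-hydroxyethyl)amino has an oxygen and hydrogen-bond donors while dimethylamino has neither, and no measurement here explains why the number rises.

The compounds shown leave open whether the oxygen or the hydrogen on the nitrogen matters more, a question that methylamino and 2-methoxyethylamino at this place, with the rest of compound 1 unchanged, would help to separate. Also open, from the compounds shown here alone, is whether the same swap would have an effect of similar size with the other aromatic groups carried by compound 2 and compound 3.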